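Swapping nitro for methoxy on compound 1

The compounds below may be only part of what the source reports. "The series", "measured", "known", "first", "only" and "open" are said of these compounds alone.

- compound 1 `CC1=NN(c2ccccc2)C(=O)[C@]12C(=O)C=CC[C@H]2c1ccccc1[N+](=O)[O-]`: 32400 nM
- compound 2 `CC1=NN(c2ccccc2)C(=O)[C@@]12C(=O)C=CC[C@@H]2c1ccccc1[N+](=O)[O-]`: 68300 nM
- compound 3 `CC1=NN(c2ccccc2)C(=O)[C@]12C(=O)C=CC[C@@H]2c1cccc(C)c1`: 8000 nM

In a functional assay on MDA-MB-231 cells (Homo sapiens) for inhibition, read by MTT assay, with a stated time of 72 h (on this read-out higher numbers stand for weaker inhibition and lower numbers for stronger inhibition), compound 1 gives 32400 nM, the second highest of the three numbers. Its mirror image sits above it, with a 2.1-fold higher number from compound 1 to compound 2 (0.32 log units; beyond the scatter), while compound 3 lies well on the other side of it and gives 8000 nM.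

The next molecule is compound 4 `COc1ccccc1[C@@H]1CC=CC(=O)[C@]12C(=O)N(c1ccccc1)N=C2C`, which carries methoxy in place of nitro on an aromatic carbon. For the measured compounds named here, no measured pair shows this swap directly. Going by the values given here, the only measured step, a 2.1-fold higher number from compound 1 to compound 2 (0.32 log units; beyond the scatter), is a loose guide due to the fact that compounds 1 and 2 differ only in the configuration as drawn. It does show that numbers in this small set can move beyond the scatter, though only modestly.

Compound 3, at 8000 nM, shows that a lower number is reachable in this assay, so a modest move in that direction seems the better guess, with real uncertainty either way. The expected change is a 1.6-fold lower number from compound 1 to compound 4 (0.21 log units; within the scatter). For compound 4 the estimated value is 20000 nM, with an expected range of 6000 nM to 60000 nM.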

Compound 4, half-maximal inhibitory concentration: 5140 nM
Compound 4: the middle estimate sits 3.9-fold (0.59 log units) above what was measured, outside the stated range (below it).
By their numbers in this assay, from the lowest: compounds 4 and 3 (each within the scatter of the next); then compound 1; then compound 2.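

Swapping the group at this place, on an aromatic carbon ortho to a large group, changes the result far beyond the scatter: this assay gives a 6.3-fold lower number from compound 1 to compound 4 (0.80 log units; beyond the scatter). Before this, the only measured step within a pair was a change of configuration, so this is the first direct sign that the group itself matters here, with 2-nitrophenyl giving way to 2-methoxyphenyl on an otherwise unchanged core. Nothing given here explains why this swap lowers the number.

A single pair cannot tell whether the lower number comes from losing nitro or from gaining methoxy. On these data alone, an amine, a hydroxyl group or a plain hydrogen at the same place would help separate the two, and whether methoxy has the same effect elsewhere on the ring remains open.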